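Replacing the Carboxymethyl Arm with Diethylamino in Compound 4

The source may report more compounds than this note shows. Statements on the series, on what has been measured and on what is new or still open speak of the compounds shown alone.

Among the three measured compounds, compound 3 `COc1cc(OC)c(C(=O)/C=C/c2ccccc2Cl)c(O)c1CN(C)CC(=O)O` gives the highest number in a functional assay on PC-3 cells (Homo sapiens) for antiproliferative activity, with a stated time of 72 h (a higher number here means a weaker inhibitor, a lower number a stronger inhibitor), at 12500 nM. Its nearest neighbour is compound 1 `COC(=O)CN(C)Cc1c(OC)cc(OC)c(C(=O)/C=C/c2ccccc2Cl)c1O`, which gives 7200 nM, a gap within the scatter; the furthest is compound 2 `COc1cc(OC)c(C(=O)/C=C/c2ccccc2Cl)c(O)c1CN1CCCC1`, which gives 3100 nM, with a 4.0-fold higher number from compound 2 to compound 3 (0.61 log units; beyond the scatter). The unmeasured compound 4 `CCN(CC)Cc1c(OC)cc(OC)c(C(=O)/C=C/c2ccccc2Cl)c1O` differs from compound 3 at one site: diethylamino in place of (carboxymethyl)(methyl)amino on a saturated chain carbon bound to an aromatic carbon. For the measured compounds named here, two measured steps bear on this change. The step of a 4.0-fold higher number from compound 2 to compound 3 (0.61 log units; beyond the scatter) shows that bringing in the carboxymethyl group raised the number, and the step of a 2.3-fold lower number from compound 1 to compound 2 (0.37 log units; beyond the scatter) shows that an amine with no hydrogen-bond donor gave the lowest number of the set. Since compound 4 also carries an amine with no hydrogen-bond donor, a lower number than compound 3 is expected, with the step of a 3.6-fold lower number from compound 3 to compound 4 (0.55 log units; beyond the scatter) bringing it close to compound 2. Compound 4 is therefore estimated at 3500 nM in this assay, within a range from 1500 nM to 8000 nM.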

Compound 4, half-maximal inhibitory concentration: 4200 nM
Compound 4: middle estimate off by 1.2-fold (0.08 log units), on the low side, within the range that was stated.
By their numbers in this assay, from the lowest: compounds 2, 4, 1 and 3 (each within the scatter of the next, the first and the last beyond it).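

In this assay, diethylamino on a saturated chain carbon bound to an aromatic carbon stands clearly apart from (carboxymethyl)(methyl)amino (a 3.0-fold lower number from compound 3 to compound 4 (0.47 log units; beyond the scatter)), so the difference earlier seen with pyrrolidin-1-yl now also appears with an amine that has no ring. Diethylamino and pyrrolidin-1-yl do not separate at this place (a 1.4-fold higher number from compound 2 to compound 4 (0.13 log units; within the scatter)), so the open chain and the ring give numbers within the scatter of each other. Diethylamino does not separate from the ((methoxycarbonyl)methyl)(methyl)amino arm either (a 1.7-fold lower number from compound 1 to compound 4 (0.23 log units; within the scatter)), which leaves compound 4 unresolved from both compound 1 and compound 2. No measurement shown here accounts for these steps. As far as these compounds go, how a morpholine, a piperidine, a secondary amine or a longer chain ending in a carboxylic acid would behave at this place remains open.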